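A few compounds are considered here, and "the series" means these few. Any claim that something is new, unique, unknown or untested is made for them only; others in the source may bear on it.

Of the compounds shown here, two of the shared core have been measured in a functional assay on HeLa cells (Homo sapiens) for antiproliferative activity, read by CCK-8 assay, with a stated time of 72 h; on this read-out higher numbers stand for weaker inhibition and lower numbers for stronger inhibition. Compound 1 `O=C(Nc1cccc(-c2oc3cc(-c4ccc(F)cc4)ccc3c(=O)c2O)c1)c1ccc(F)cc1` gives 5350 nM, and compound 2 `O=C(Nc1cccc(-c2oc3cc(-c4ccc(F)cc4)ccc3c(=O)c2O)c1)c1ccc(Br)cc1` gives 9740 nM. Among the compounds with values here, the only measured step is a 1.8-fold higher number from compound 1 to compound 2 (0.26 log units; within the scatter), so compound 2 holds the highest of the two numbers, with compound 1 as its nearest neighbour, and the two sit within the scatter of each other. Compound 3 `O=C(Nc1cccc(-c2oc3cc(-c4ccc(F)cc4)ccc3c(=O)c2O)c1)c1cccc(F)c1` differs from compound 2 in one place: 3-fluorophenyl in place of 4-bromophenyl on a carbonyl carbon. Within the data shown here, no measured step covers this exact exchange; the one step that exists swaps a halogen on the same ring and stayed within the scatter. The expected step is therefore a 1.5-fold lower number from compound 2 to compound 3 (0.18 log units; within the scatter), a shift within the scatter, leaning toward the number that the fluoro-bearing compound 1 showed. For compound 3 the estimated value in this assay is 6500 nM, with a range from 3000 nM to 14000 nM.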

Compound 3, half-maximal inhibitory concentration: 8780 nM
For compound 3 the middle estimate is 1.4-fold (0.13 log units) below the measured one; the range from low to high includes it.
By their numbers in this assay, from the lowest: compounds 1, 3 and 2 (each within the scatter of the next).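

In this assay, 3-fluorophenyl in place of 4-bromophenyl on a carbonyl carbon gives a 1.1-fold lower number from compound 2 to compound 3 (0.05 log units; within the scatter), and 3-fluorophenyl in place of 4-fluorophenyl gives a 1.6-fold higher number from compound 1 to compound 3 (0.22 log units; within the scatter), both within the scatter. Compound 3 thus adds a second kind of exchange to the halogen swap seen earlier: the fluoro now stands on a different ring carbon, and compounds 1, 2 and 3 remain within the scatter of one another, so neither the halogen nor its ring position separates them here. Nothing measured alongside these numbers offers an explanation for this result.

As far as these compounds go, all three compounds carry a single halogen on this phenyl ring, so the effect of an amine, a carboxylic acid or a methoxy group there remains open. Also open, from the compounds shown here alone, is what a saturated alkyl chain would do in place of the ring on the carbonyl carbon.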